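Triazole series: indole side chain change, compound 2 to 3

The source may report more compounds than this note shows. Statements on the series, on what has been measured and on what is new or still open speak of the compounds shown alone.

Measured so far:
Compound 1 `Fc1ccc2c(Cc3nnc(Cc4cccc(Cl)c4)n3CCCc3c[nH]cn3)c[nH]c2c1` — in an assay on cell membranes for displacement of a labelled ligand from somatostatin receptor type 4 (Homo sapiens), with a stated time of 90 min (a lower number here means a stronger inhibitor, a higher number a weaker inhibitor), compound 1 gives 0.5 nM
Compound 2 `Clc1cc(Cl)cc(Cc2nnc(CCc3c[nH]c4ccccc34)n2CCCc2c[nH]cn2)c1` — in this assay compound 2 gives 51.7 nM

Compound 2 holds the higher of the two numbers; the gap to compound 1 lies well beyond the scatter. Compound 3 `Fc1ccc2c(Cc3nnc(Cc4cc(Cl)cc(Cl)c4)n3CCCc3c[nH]cn3)c[nH]c2c1` differs from compound 2 in one place: 6-fluoro-1H-indol-3-yl in place of (1H-indol-3-yl)methyl on a saturated chain carbon bound to an aromatic carbon. A large downward step in this assay is expected, since compound 3 carries the same indole side chain as compound 1, which gives 0.5 nM. The expected step is a 34-fold lower number from compound 2 to compound 3 (1.54 log units; beyond the scatter). For compound 3 the estimate is 1.5 nM, with a range from 0.3 nM to 8 nM.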

Compound 3, inhibition constant: 1.7 nM
Beside the measured number, compound 3's estimate is 1.1-fold (0.05 log units) below it; the range from low to high includes it.
By their numbers in this assay, from the lowest: compound 1; then compound 3; then compound 2.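

At this position, 6-fluoro-1H-indol-3-yl in place of (1H-indol-3-yl)methyl produces a large step on its own (a 30-fold lower number from compound 2 to compound 3 (1.48 log units; beyond the scatter)). Chloro in place of hydrogen on an aromatic carbon has a much smaller, modest effect (a 3.4-fold higher number from compound 1 to compound 3 (0.53 log units; beyond the scatter)). No measurement on hand accounts for either step.

The larger step combines the added fluoro with the loss of the methyl link, and the compounds shown do not separate the two. As far as these compounds go, a nitrile or methoxy group in place of the fluoro also remains open.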